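From furan-3-yl to furan-2-yl on a shared core

This account rests on a few compounds, and the source may have more. Where it says the series, first, only, none or still open, it means among the compounds named here.

compound 1 `CCOC(=O)CCCCCOc1cccc(CN(C(=O)c2ccc(-c3cccc(NC(C)=O)c3)cc2)C(C)C)c1` gives > 26000 nM
compound 2 `CCOC(=O)CCCCCOc1cccc(CN(C(=O)c2ccc(-c3cccc(C(C)=O)c3)cc2)C(C)C)c1` gives > 26000 nM
compound 3 `CCOC(=O)CCCCCOc1cccc(CN(C(=O)c2ccc(-c3ccoc3)cc2)C(C)C)c1` gives > 26000 nM

Each of these entries is a limit and not a number. In an ADME assay on HepG2 cells (Homo sapiens) for cytotoxicity, read by CellTiter-Glo and resazurin assay, with a stated time of 72 h (on this read-out lower numbers stand for an effect already at smaller amounts and higher numbers for an effect only at larger amounts of compound), compound 3 gives > 26000 nM and this is a limit. Compound 3 thus stands at the limit of > 26000 nM in this assay, at which 3 of the 3 values shown sit, and no order among the three can be read.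

Compound 4 `CCOC(=O)CCCCCOc1cccc(CN(C(=O)c2ccc(-c3ccco3)cc2)C(C)C)c1` changes one thing: furan-2-yl in place of furan-3-yl on an aromatic carbon and the two have the same atoms, joined differently. The swap is furan-2-yl in place of furan-3-yl on an aromatic carbon.

Two measured steps replace the group at this place, namely a step that the two limits leave unreadable from compound 1 to compound 3 and a step that the two limits leave unreadable from compound 2 to compound 3 with no size to carry over. The step that the two limits leave unreadable from compound 1 to compound 2 is no more telling. No step beyond the usual scatter is therefore expected in this assay and no direction can be given.

The expected step is a step that the limit leaves unreadable from compound 3 to compound 4 and the result may well be a limit again. For compound 4 the estimate is 30000 nM within an expected range of 15000 nM to 60000 nM in this measurement.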

Compound 4, half-maximal effective concentration: > 26000 nM
Compound 4: only a limit was reported; the forecaster's own chance of this, stated with the estimate: 80%; the middle value lies beyond the limit too.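

Compound 4 also gives only a limit in this assay, so no step among compound 1, compound 2, compound 3 and compound 4 can be read: the limit of > 26000 nM in this assay, at which 4 of the 4 values shown sit.

The compounds shown leave open at what concentration any of the four would affect these cells, and how the four groups at this place compare.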